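A few compounds are considered here, and "the series" means these few. Any claim that something is new, unique, unknown or untested is made for them only; others in the source may bear on it.

Of the compounds shown here, three sharing one core have been measured in a functional assay on HEK293 cells for agonist activity at melatonin receptor type 1B (Homo sapiens), read by calcium flux; a higher number here means that more compound is needed for the effect, a lower number that less compound is needed. Compound 1 `COc1cc2c(CO)coc2cc1C`, which carries a hydroxy group on a saturated chain carbon bound to an aromatic carbon, gives 520000 nM in this assay. Compound 2 `COc1cc2c(CN)coc2cc1C` gives 350000 nM, and compound 3 `COc1cc2c(CN(C)C)coc2cc1C` gives 130000 nM. The step of a 1.5-fold lower number from compound 1 to compound 2 (0.17 log units; within the scatter) lies within the scatter, whereas a 4.0-fold lower number from compound 1 to compound 3 (0.60 log units; beyond the scatter) and a 2.7-fold lower number from compound 2 to compound 3 (0.43 log units; beyond the scatter) lie beyond it, so compound 3 stands lowest of the three numbers, with compound 2 nearest and compound 1 furthest.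

Compound 4 `CCN(CC)Cc1coc2cc(C)c(OC)cc12` continues along the same line: diethylamino in place of dimethylamino on a saturated chain carbon bound to an aromatic carbon. The two measured steps that bear on this change are a 2.7-fold lower number from compound 2 to compound 3 (0.43 log units; beyond the scatter) and a 4.0-fold lower number from compound 1 to compound 3 (0.60 log units; beyond the scatter), both modest and both toward a lower number as the group on the saturated chain carbon bound to an aromatic carbon grew from hydroxy or amino to dimethylamino. Among the measured compounds shown here, no measured pair shows whether a further enlargement to diethylamino carries that trend on, so the expectation is a small lowering or none beyond the scatter. Compound 4 is therefore expected to give 80000 nM in this assay, within a range of 30000 nM to 250000 nM. That estimate corresponds to an expected step of a 1.6-fold lower number from compound 3 to compound 4 (0.21 log units; within the scatter).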

Compound 4, half-maximal effective concentration: 360000 nM
The estimate for compound 4 lay 4.5-fold (0.65 log units) below the measured number, outside the stated range (above it).
By their numbers in this assay, from the lowest: compound 3; then compounds 2, 4 and 1 (each within the scatter of the next).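

In this assay, among the compounds shown here, the earlier compounds showed the number falling as the group on the saturated chain carbon bound to an aromatic carbon went from amino or hydroxy to dimethylamino, but the larger diethylamino group runs the other way, with a 2.8-fold higher number from compound 3 to compound 4 (0.44 log units; beyond the scatter) beyond the scatter. The lower number of compound 3 does not carry over to diethylamino, since a 1.0-fold higher number from compound 2 to compound 4 (0.01 log units; within the scatter) and a 1.4-fold lower number from compound 1 to compound 4 (0.16 log units; within the scatter) both lie within the scatter, leaving compound 4 not distinguishable from the amino and hydroxy compounds. Adding heavy atoms to the amine at this position therefore does not steadily lower the number, and among these four compounds dimethylamino alone stands apart, though nothing measured here offers a reason for the reversal.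

Going by these compounds, it remains open whether the low point belongs to dimethylamino itself or would also appear with methylamino, ethylamino or ethylmethylamino, the groups that would fill in the steps around it. Ring amines such as pyrrolidine or piperidine at this position, which tie the carbon chains on the nitrogen back into a ring, are also left open, as is whether any amine here could bring the number far below those seen so far.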